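Furan in Place of Hydroxybutenolide on a Diterpene Scaffold

The source may hold more compounds than are shown below. What is called first, only, known or untested is meant among the compounds shown, and "the series" means these compounds.

Measured so far:
- compound 1, `C=C(C)CCC[C@]1(C)C2=CCC[C@](C)(C[C@H](O)c3ccoc3)[C@H]2CC[C@H]1C`: 63100 nM
- compound 2, `C=C(C)CC[C@]1(C)C2=CCC[C@](C)(C[C@H](O)C3=CC(=O)OC3O)[C@H]2CC[C@H]1C`: 3200 nM

Both compounds were tested in a functional assay on HT-29 cells (Homo sapiens) for antiproliferative activity, read by XTT assay, with a stated time of 72 h; on this read-out lower numbers stand for stronger inhibition and higher numbers for weaker inhibition. Compound 2 holds the lowest of the two numbers; its nearest neighbour, compound 1, gives a number higher by more than the usual scatter, so compound 2 is the stronger inhibitor of the pair.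

Compound 3, `C=C(C)CC[C@]1(C)C2=CCC[C@](C)(C[C@H](O)c3ccoc3)[C@H]2CC[C@H]1C`, has not yet been measured. It differs from compound 2 in one place: a group of 5 heavy atoms (4 carbon, 1 oxygen; one five-membered aromatic ring with 1 hetero atom) in place of a group of 7 heavy atoms (4 carbon, 3 oxygen; one five-membered non-aromatic ring with 1 hetero atom), on a saturated chain carbon bound to an oxygen on a saturated carbon and a saturated chain carbon. For the measured compounds named here, no step between measured compounds carries this exact change. Compound 1, whose structure also carries a furan-3-yl group but differs from compound 3 elsewhere, gives the far weaker value of the two measured compounds.

On that basis the step from compound 2 to compound 3 is expected to be large and toward weaker inhibition, with an estimated step of a 9.4-fold higher number from compound 2 to compound 3 (0.97 log units; beyond the scatter). Compound 3 is therefore estimated to give 30000 nM, with a range from 8000 nM to 100000 nM.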

Compound 3, half-maximal inhibitory concentration: 30000 nM
For compound 3 middle estimate and measured number coincide at the digits printed, within the range that was stated.
By their numbers in this assay, from the lowest: compound 2; then compound 3; then compound 1.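

With the side chain held constant, swapping the hydroxybutenolide of compound 2 for furan-3-yl gives a 9.4-fold higher number from compound 2 to compound 3 (0.97 log units; beyond the scatter) in this assay, so this change at the saturated chain carbon can now be read on its own, whereas compound 1 and compound 2 differ in two places at once. The other new step isolates the chain with furan-3-yl held constant: 1-methylethenyl in place of 2-methylprop-2-en-1-yl gives a 2.1-fold lower number from compound 1 to compound 3 (0.32 log units; beyond the scatter), which shows that the chain end also affects the read-out, although the step is printed as only just beyond the usual scatter. No measurement here explains why either change shifts the antiproliferative number.

The hydroxybutenolide differs from furan-3-yl in several ways at once, including its ring type and its counts of hydrogen-bond donors and acceptors, so these two compounds cannot show which difference matters; a butenolide without the ring hydroxyl, or a carboxylic acid at the same carbon, would help to separate them. The effect of the chain is also known only from a single pair with furan-3-yl, leaving open how the same chain change behaves with the hydroxybutenolide in place, or how a longer chain or an amine at the chain end would read.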